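Three Carbonyl Substituents Measured, an Isopropylamide Awaited

The compounds below may be only part of what the source reports. "The series", "measured", "known", "first", "only" and "open" are said of these compounds alone.

Three compounds have been measured in a functional assay on the whole organism for inhibition, with Rattus norvegicus as the target, read by paw edema, with stated times of 30 min and 5 h, at a dose of 0.28 mmol/kg by the oral route; a higher number here means more inhibition at the dose given (going by the name of the read-out), a lower number less inhibition:

Compound 1 `CC(=O)c1ccc(NC(=O)c2nc(-c3ccccc3)n(-c3ccc(S(N)(=O)=O)cc3)n2)cc1` gives 42%.
Compound 2 `NC(=O)c1nc(-c2ccccc2)n(-c2ccc(S(N)(=O)=O)cc2)n1` gives 42%.
Compound 3 `COC(=O)c1nc(-c2ccccc2)n(-c2ccc(S(N)(=O)=O)cc2)n1` gives 46%.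

Compound 3 stands at the top of these three numbers, but only within the scatter: a number 4 percentage points higher from compound 1 to compound 3 (within the scatter) and a number 4 percentage points higher from compound 2 to compound 3 (within the scatter). Likewise no change at the digits printed from compound 1 to compound 2 (within the scatter), so the three measured compounds cannot be told apart on the numbers shown.

Compound 4 `CC(C)NC(=O)c1nc(-c2ccccc2)n(-c2ccc(S(N)(=O)=O)cc2)n1` has not yet been measured. It differs from compound 3 in one place: isopropylamino in place of methoxy on a carbonyl carbon.

Two of the measured steps bear directly on this change, since each of them also swaps the group on the carbonyl carbon. From amino to methoxy the step was a number 4 percentage points higher from compound 2 to compound 3 (within the scatter), and from (4-acetylphenyl)amino to methoxy it was a number 4 percentage points higher from compound 1 to compound 3 (within the scatter); neither step left the scatter. A small amino, a large aryl-substituted amino and a methoxy all gave the same read-out within noise, and the isopropylamino group of compound 4 sits at this same carbonyl carbon. No step beyond the scatter is therefore expected in this assay for compound 4, in either direction.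

The estimate for compound 4 is 44%, with a range from 32% to 56%, which is an expected step of a number 2 percentage points lower from compound 3 to compound 4 (within the scatter).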

Compound 4, a percentage reported as inhibition, in the whole organism at one dose (the size of the read-out at that dose, not a potency): 43%
For compound 4 the middle estimate is 1 percentage points above the measured one; the range from low to high includes it.
By their numbers in this assay, from the lowest: compounds 1, 2, 4 and 3 (each within the scatter of the next).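

In this assay, the isopropylamino group on the carbonyl carbon gave a number 3 percentage points lower from compound 3 to compound 4 (within the scatter), so an alkyl-substituted amino group can stand in place of methoxy there without a step that leaves the scatter. On the amide-type nitrogen itself, isopropyl in place of hydrogen gave a number 1 percentage points higher from compound 2 to compound 4 (within the scatter), and isopropyl in place of 4-acetylphenyl gave a number 1 percentage points higher from compound 1 to compound 4 (within the scatter), which adds an alkyl group to the hydrogen and the aryl group already seen on that nitrogen and leaves all three indistinguishable, with methoxy on the carbonyl carbon also within the scatter of each. No measurement shown offers an explanation for this flat result at this position.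

From the compounds shown here alone, what remains open is whether any group on this carbonyl carbon would move the read-out beyond the scatter, for instance a free carboxylic acid, a dimethylamino group with no amide hydrogen, or a longer chain on the amide nitrogen. Since every value was taken at a single oral dose, the compounds shown also leave open whether those that cannot be told apart here would stay so at other doses.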